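Series notes: from compound 2 toward compound 3

This account rests on a few compounds, and the source may have more. Where it says the series, first, only, none or still open, it means among the compounds named here.

Among the compounds with values here, in a functional assay on HepG2 cells (Homo sapiens) for antiproliferative activity, read by MTT assay, with a stated time of 24 h (a higher number here means a weaker inhibitor, a lower number a stronger inhibitor), compound 2 `COc1cc(OC)c(-c2coc3cc(OCc4ccccc4C)ccc3c2=O)cc1OC` gives 1860 nM, the only number in the set. Compound 1 `COc1cc(OC)c(-c2coc3cc(OCC(=O)c4cccc(C(F)(F)F)c4)ccc3c2=O)cc1OC` reports a limit rather than a number, > 10000 nM. That is the limit of > 10000 nM in this assay, at which 1 of the 2 values shown sits. Within the data shown here, the sole measured step, an at least 5.3-fold lower number from compound 1 to compound 2 (0.73 log units; beyond the scatter), alters a different part of the side chain and so does not bear on compound 3 `COc1cc(OC)c(-c2coc3cc(OCc4cccc(Cl)c4)ccc3c2=O)cc1OC`, where (3-chlorophenyl in place of 2-methylphenyl on a saturated chain carbon bound to an oxygen on an aromatic ring). Without a measured step of this kind, no change beyond the scatter is expected, and compound 3 is estimated at 1800 nM (range 600 nM to 5500 nM), which means an expected 1.0-fold lower number from compound 2 to compound 3 (0.01 log units; within the scatter).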

Compound 3, half-maximal inhibitory concentration: 750 nM
For compound 3 the middle estimate is 2.4-fold (0.38 log units) above the measured one; measured number inside the range.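

In this assay the aryl group on the saturated chain carbon bound to an oxygen on an aromatic ring does move the number: 3-chlorophenyl in place of 2-methylphenyl gives a 2.5-fold lower number from compound 2 to compound 3 (0.39 log units; beyond the scatter). Leaving the carbonyl-bearing side chain for 3-chlorophenyl gives an at least 13-fold lower number from compound 1 to compound 3 (1.12 log units; beyond the scatter). Compound 1 reports a limit rather than a number: the limit of > 10000 nM in this assay, at which 1 of the 3 values shown sits.

The chlorine and its place on the ring cannot be separated, since both differ at once from the methyl of compound 2. As far as these compounds go, how an amine or a carboxylic acid on that ring, or a longer chain to it, would read remains open.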